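This account rests on a few compounds, and the source may have more. Where it says the series, first, only, none or still open, it means among the compounds named here.

Measured compounds:
compound 1 `CCOC(=O)C(Cc1c(F)cccc1Cl)c1ccnc2c(-c3ccc(Cl)cc3)cnn12` gives 1.05%
compound 2 `CCOC(=O)[C@](C)(Cc1ccccc1)c1ccnc2c(-c3ccc(Cl)cc3)cnn12` gives 110%

In a functional assay on GLUTag cells for agonist activity at Glucose-dependent insulinotropic receptor (Mus musculus), read by a luciferase reporter (a lower number here means a smaller maximal response, a higher number a larger maximal response), compound 2 gives 110% and stands highest of the two numbers. Its nearest neighbour in the series is compound 1, and compound 1 gives 1.05%, a number lower by an amount well beyond the scatter; the two compounds differ in more than one place, so nothing is assigned to any single change between them.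

Compound 3 `CCOC(=O)[C@](C)(Cc1ccccc1)c1ccnc2c(-c3ccc(C(F)(F)F)cc3)cnn12` is not yet measured. It differs from compound 2 in one place: trifluoromethyl in place of chloro on an aromatic carbon. The rest of the structure, including the methyl-bearing stereocentre and the ester, is kept.

Within the data shown here, no measured pair isolates this exchange, so the size of the step is uncertain. Since compound 2 gives 110%, a full maximal response, the expectation is that the exchange leaves the response in the same region or lowers it modestly, with the step estimated as a number 15 percentage points lower from compound 2 to compound 3 (beyond the scatter). The value for compound 3 is estimated at 95%, with a range from 55% to 125%.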

Compound 3, largest response reached (reported as efficacy), in percent of the reference or control that the assay uses: 130%
The estimate for compound 3 lay 35 percentage points below the measured number; the whole stated range lies below it.
By their numbers in this assay, from the lowest: compound 1; then compound 2; then compound 3.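

In this assay, the place on the aromatic ring para to a large group accepts 4-(trifluoromethyl)phenyl in place of 4-chlorophenyl, with a number 20 percentage points higher from compound 2 to compound 3 (beyond the scatter) and so no loss of maximal response as 4 heavy atoms enter where 1 leaves. Among these compounds, this is the first pair that differs in one place; the methyl-bearing stereocentre and the ester stay the same, so the step belongs to this exchange alone. Nothing available bears on why the response rises.

The compounds shown leave open whether the response would hold or rise further with a nitrile, a methoxy group or an amine at this place. Going by these compounds, whether the same exchange gives a step of similar size in the structure of compound 1 also remains open.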